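Moving the methoxy group on a benzylamine sulfonamide

A few compounds are considered here, and "the series" means these few. Any claim that something is new, unique, unknown or untested is made for them only; others in the source may bear on it.

Within the data shown here, compound 2 `COc1cccc(CNCCCNS(=O)(=O)c2cc(C(F)(F)F)cc(C(F)(F)F)c2)c1` gives 2400 nM in a functional assay on MCF7 cells (Homo sapiens) for inhibition, read by MTT assay, with a stated time of 72 h (a higher number here means a weaker inhibitor of growth, a lower number a stronger inhibitor of growth), and the only other measured compound, compound 1 `O=S(=O)(NCCCNCC1COc2ccccc2O1)c1cc(C(F)(F)F)cc(C(F)(F)F)c1`, gives 2500 nM, so the two lie within the scatter of each other, as the step of a 1.0-fold lower number from compound 1 to compound 2 (0.02 log units; within the scatter) shows. Compound 3 `COc1ccccc1CNCCCNS(=O)(=O)c1cc(C(F)(F)F)cc(C(F)(F)F)c1` differs from compound 2 by 2-methoxyphenyl in place of 3-methoxyphenyl on a saturated chain carbon bound to an amine nitrogen. Among the measured compounds shown here, no measured step moves a methoxy group around its ring; the one comparison at the same place, from compound 1 to compound 2, lies within the scatter. A step of no change at the digits printed from compound 2 to compound 3 (within the scatter) is therefore expected, none beyond the scatter. Compound 3 is estimated at 2400 nM, between 1000 nM and 6000 nM.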

Compound 3, concentration for 50% growth inhibition: 2600 nM
For compound 3 the middle estimate is 1.1-fold (0.03 log units) below the measured one, and the stated range covers the measured number.
By their numbers in this assay, from the lowest: compounds 2, 1 and 3 (each within the scatter of the next).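

Moving the methoxy group around its ring gives a 1.1-fold higher number from compound 2 to compound 3 (0.03 log units; within the scatter) in this assay, a comparison the earlier compounds did not offer. Replacing the 2,3-dihydro-1,4-benzodioxin-2-yl group with 2-methoxyphenyl gives a 1.0-fold higher number from compound 1 to compound 3 (0.02 log units; within the scatter) as well, so all three groups at this place read alike in this assay. No measurement here offers a reason for this flat result. The compounds shown leave open whether a plain phenyl, a pyridine ring or a carboxylic acid at this place would shift the number beyond the scatter.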